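From 3-Nitrophenyl to 4-Methylphenyl on the Shared Core

This account rests on a few compounds, and the source may have more. Where it says the series, first, only, none or still open, it means among the compounds named here.

Within the data shown here, in a functional assay on SGC-7901 cells (Homo sapiens) for antiproliferative activity, read by MTT assay, with a stated time of 72 h (on this read-out lower numbers stand for stronger inhibition and higher numbers for weaker inhibition), compound 2 (`COc1cc(-n2cnc3ccc(-c4cccc([N+](=O)[O-])c4)cc32)cc(OC)c1OC`) gives 380 nM, the only true number available so far. Compound 1 (`COc1cc(-n2cnc3ccc(-c4ccccc4Cl)cc32)cc(OC)c1OC`) gives > 10000 nM, which is a limit. Among the measured compounds shown here, the one measured step, an at least 26-fold lower number from compound 1 to compound 2 (1.42 log units; beyond the scatter), exchanges 2-chlorophenyl for 3-nitrophenyl and shows that a change at this aromatic carbon can shift the read-out strongly. Compound 3 (`COc1cc(-n2cnc3ccc(-c4ccc(C)cc4)cc32)cc(OC)c1OC`) carries 4-methylphenyl in place of 3-nitrophenyl at the same carbon: 4-methylphenyl in place of 3-nitrophenyl on an aromatic carbon. Neither measured compound carries this group, so the large step of an at least 26-fold lower number from compound 1 to compound 2 (1.42 log units; beyond the scatter) warns of sensitivity here but fixes neither size nor direction. A modest rise in the number is expected in this assay, with a wide margin on either side, and the estimated step is a 2.4-fold higher number from compound 2 to compound 3 (0.37 log units; beyond the scatter). For compound 3 the expected value is 900 nM, within an estimated range from 150 nM to 6000 nM.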

Compound 3, half-maximal inhibitory concentration: 200 nM
The estimate for compound 3 lay 4.5-fold (0.65 log units) above the measured number; the range from low to high includes it.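

In this assay, 4-methylphenyl and 3-nitrophenyl cannot be told apart: the exchange gives a 1.9-fold lower number from compound 2 to compound 3 (0.28 log units; within the scatter), even though 4-methylphenyl has no hydrogen-bond acceptors and 3-nitrophenyl has them, so this position tolerates two quite different groups. Among these compounds, the step of an at least 50-fold lower number from compound 1 to compound 3 (1.69 log units; beyond the scatter) is large and matches the earlier step from compound 1, which leaves 2-chlorophenyl as the only one of the three groups with a weak read-out. Compound 1 stands at a limit, so this step has no fixed size: the limit of > 10000 nM in this assay, at which 1 of the 3 values shown sits.

As far as these compounds go, what separates 2-chlorophenyl from the other two groups remains open, since the three differ both in the substituent and in where it sits on the ring, and 4-chlorophenyl would help to separate these. From the compounds shown here alone, how an amine or a carboxylic acid on this phenyl ring would behave also remains open.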